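Series notes: nitro in place of trifluoromethyl on the benzyl ether

The compounds below may be only part of what the source reports. "The series", "measured", "known", "first", "only" and "open" are said of these compounds alone.

Measured so far:
compound 1, `c1ccc(COc2ccccc2Nc2ncnc3cc4c(cc23)OCCOCCOCCO4)cc1`: 6940 nM
compound 2, `FC(F)(F)c1ccc(COc2cccc(Nc3ncnc4cc5c(cc34)OCCOCCOCCOCCO5)c2)cc1`: 8520 nM

In a functional assay on A549 cells (Homo sapiens) for antiproliferative activity, read by MTT assay, with a stated time of 72 h (on this read-out lower numbers stand for stronger inhibition and higher numbers for weaker inhibition), compound 2 gives 8520 nM, the higher of the two numbers measured. Compound 1 gives 6940 nM in this assay; the two values lie within the scatter of each other, so no order between them can be read. Going by the values given here, compound 1 and compound 2 differ in more than one place, and no single step connects them.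

Compound 3, `O=[N+]([O-])c1ccc(COc2cccc(Nc3ncnc4cc5c(cc34)OCCOCCOCCOCCO5)c2)cc1`, is not yet measured. It differs from compound 2 in one place: nitro in place of trifluoromethyl on an aromatic carbon. Among the compounds with values here, no measured pair shows a step of this kind, so nothing here sizes it. The expectation for this assay is a step from compound 2 to compound 3 of a 1.2-fold lower number from compound 2 to compound 3 (0.09 log units; within the scatter), which is no change beyond the scatter. For compound 3 the estimated value in this assay is 7000 nM, with a range from 2500 nM to 20000 nM.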

Compound 3, half-maximal inhibitory concentration: 19800 nM
The estimate for compound 3 lay 2.8-fold (0.45 log units) below the measured number; measured number inside the range.
By their numbers in this assay, from the lowest: compounds 1 and 2 (each within the scatter of the next); then compound 3.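

Working notes: this is the first single-place step in the series. In this assay, (4-(trifluoromethyl)benzyl)oxy to (4-nitrobenzyl)oxy gives a 2.3-fold higher number from compound 2 to compound 3 (0.37 log units; beyond the scatter) and moves the number toward weaker inhibition, so the group at this place on the benzyl ether is not silent in this read-out, which the comparison of compound 1 with compound 2 could not show. No measured property of either group accompanies the step, and the data offer no account of it.

Open, as far as these compounds go, is whether an amine, a carboxylic acid or a nitrile at this same place would shift the number further or return it toward that of compound 2. Also open, from the compounds shown here alone, is whether the same exchange gives a step of similar size on the core of compound 1.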